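Chalcone series on the shared core: bromophenyl to nitrophenyl

The source may report more compounds than this note shows. Statements on the series, on what has been measured and on what is new or still open speak of the compounds shown alone.

Among the compounds with values here, compound 1 `O=C(COc1ccc(C(=O)/C=C/c2ccccc2Br)cc1)N[C@H]1CCOC1=O` carries a chalcone arm on the shared core, and in a functional assay on MCF7 cells (Homo sapiens) for antiproliferative activity, read by MTT assay, with a stated time of 72 h (on this read-out higher numbers stand for weaker inhibition and lower numbers for stronger inhibition), compound 1 gives 15300 nM, the only numerical value among the three measured members. Compound 2 `O=C(CNc1ccccc1)N[C@H]1CCOC1=O` reaches only a limit of the assay in this assay at > 64000 nM. Compound 3 `O=C1OCC[C@@H]1NC(=S)SCCOc1ccccc1[N+](=O)[O-]` likewise reaches only a limit in this assay, > 64000 nM. Compound 1 therefore stands alone with a number, and no pattern can be drawn from it. Compound 4 `O=C(COc1ccc(C(=O)/C=C/c2cccc([N+](=O)[O-])c2)cc1)N[C@H]1CCOC1=O` differs from compound 1 in one place: 3-nitrophenyl in place of 2-bromophenyl on a double-bonded chain carbon bound to a double-bonded chain carbon. Within the data shown here, no step between two measured compounds is available to calibrate this change. The step of a 1.0-fold lower number from compound 1 to compound 4 (0.01 log units; within the scatter) is expected to stay within the usual scatter, with no direction claimed. Compound 4 is expected to give about 15000 nM in this assay, in the range 5000 nM to 45000 nM.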

Compound 4, half-maximal inhibitory concentration: > 64000 nM
Compound 4: a limit, no number (the forecaster's own chance of this, stated with the estimate: 15%); at least 4.2-fold (0.63 log units) between middle value and limit.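

In this assay, the aryl group on a double-bonded chain carbon bound to a double-bonded chain carbon matters for the chalcone series, as 3-nitrophenyl in place of 2-bromophenyl gives an at least 4.1-fold higher number from compound 1 to compound 4 (0.62 log units; beyond the scatter). Compound 4 gives only a limit of the assay, > 64000 nM, not a number. The step therefore has a lower bound but no known size, because the read-out ends at this limit: the limit of > 64000 nM in this assay, at which 3 of the 4 values shown sit.

Still open, as far as these compounds go, is whether the change follows the nitro group or its place on the ring. A 3-bromophenyl or 2-nitrophenyl group at this position would separate the two.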